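This account rests on a few compounds, and the source may have more. Where it says the series, first, only, none or still open, it means among the compounds named here.

- compound 1 `O=C(C1CCN(C(=O)C(F)(F)F)CC1)N1N=CCC1c1ccccc1` reads 4.9
- compound 2 `O=C(C1CCN(c2cccnn2)CC1)N1N=CC[C@H]1c1ccccc1` reads 3.4

Going by the values given here, both numbers come from a physicochemical assay for lipophilicity, read by HPLC, measured as chromatographic lipophilicity, at pH 7.4 (a lower number here means a more polar compound, a higher number a more lipophilic compound), and only two compounds have been measured so far. Compound 1 stands highest of the two (4.9), and the gap down to compound 2 (3.4) lies beyond the usual scatter of repeat measurements.

Among the compounds with values here, the next compound, compound 3 `O=C(c1cc[nH]n1)N1CCC(C(=O)N2N=CCC2c2ccccc2)CC1`, has no measurement yet. It keeps the core of compound 1 and differs in one place, with 1H-pyrazol-3-yl in place of trifluoromethyl on a carbonyl carbon.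

Within the data shown here, no measured pair isolates this change, so any expectation is a judgement and not a reading from a matched step. Among the measured compounds shown here, the only guide is compound 2 (3.4), which shows how far below compound 1 a compound of similar build can read, although it differs from compound 1 in more than one place. In this assay a fall beyond the scatter is expected, and its estimated size is a number 1.20 log units lower from compound 1 to compound 3 (beyond the scatter) in all. For compound 3 the estimated value is 3.7 (range 3.1 to 4.3).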

Compound 3, distribution coefficient: 2.4
For compound 3 the middle estimate is 1.30 log units above the measured one; measured number outside the range, below it.
By their numbers in this assay, from the lowest: compound 3; then compound 2; then compound 1.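

In this assay, going by these compounds alone, the swap of trifluoromethyl for 1H-pyrazol-3-yl gives a number 2.50 log units lower from compound 1 to compound 3 (beyond the scatter), and this is the first pair that differs in one place only, on the carbonyl carbon whose other neighbour is an amide-type nitrogen in a ring. It shows that the group on this carbonyl carbon can by itself move the reading by a large amount while the rest of the molecule stays the same. The change replaces a group with no ring and 0 hydrogen-bond donors by a five-membered aromatic ring with 1 hydrogen-bond donor and 1 hydrogen-bond acceptor, but no measurement here shows which of these differences accounts for the step.

The compounds shown leave open whether a plain phenyl ring or a pyrazole carrying a methyl group on its ring nitrogen, placed on the same carbonyl carbon, would read closer to compound 1 or to compound 3. They also leave open whether the same swap would give a step of similar size on a different core.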